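The source may hold more compounds than are shown below. What is called first, only, known or untested is meant among the compounds shown, and "the series" means these compounds.

Measured compounds:
- compound 1 `COc1cc2c(Oc3ccc(NC(=O)c4nn(-c5ccccc5C)c(=O)cc4C)cc3F)ccnc2cc1OCCCN1CCCC1`: 1400 nM in a functional assay on HT-29 cells (Homo sapiens) for inhibition, read by MTT assay, with a stated time of 72 h; a higher number here means a weaker inhibitor, a lower number a stronger inhibitor
- compound 2 `COc1cc2c(Oc3ccc(NC(=O)c4nn(-c5ccccc5C)c(=O)cc4C)cc3F)ccnc2cc1OCCCN1CCCCC1`: 2810 nM in this assay

Within this pair, compound 2 gives the higher of the two numbers in this assay; the single step between them, a 2.0-fold higher number from compound 1 to compound 2 (0.30 log units; within the scatter), is within the scatter, so the two compounds cannot be ordered on these data.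

Compound 3 `COc1cc2c(Oc3ccc(NC(=O)c4nn(-c5ccccc5C)c(=O)cc4C)cc3F)ccnc2cc1OCCCN1CCC(C)CC1` is not yet measured. It differs from compound 2 in that (methyl in place of hydrogen on a saturated ring carbon). Within the data shown here, the only measured step concerns the ring on the same chain, a 2.0-fold higher number from compound 1 to compound 2 (0.30 log units; within the scatter), and it changed the number by no more than the scatter. Among the measured compounds shown here, no measured step addresses a methyl on that ring carbon, so the expectation rests on compound 2 alone and on the small size of the one nearby change.

Compound 3 is therefore expected to give a number in this assay close to that of compound 2, with the step of a 1.1-fold higher number from compound 2 to compound 3 (0.03 log units; within the scatter) expected to lie within the scatter. The estimate for compound 3 is 3000 nM, with a range from 1100 nM to 8000 nM.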

Compound 3, half-maximal inhibitory concentration: 2810 nM
Compound 3: middle estimate off by 1.1-fold (0.03 log units), on the high side; measured number inside the range.
By their numbers in this assay, from the lowest: compounds 1, 2 and 3 (each within the scatter of the next).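

In this assay, among these compounds, methyl in place of hydrogen on the ring carbon three ring bonds from the ring nitrogen gives no change at the digits printed from compound 2 to compound 3 (within the scatter), the first measured step that adds a group to this ring instead of exchanging the ring itself. Exchanging pyrrolidin-1-yl for 4-methylpiperidin-1-yl gives a 2.0-fold higher number from compound 1 to compound 3 (0.30 log units; within the scatter), so the pyrrolidin-1-yl, piperidin-1-yl and 4-methylpiperidin-1-yl chain ends cannot be ordered on these data. No supporting measurement bears on this result.

On these data alone, whether a hydroxyl, a carboxylic acid or a phenyl on this ring carbon, or a morpholine or 4-methylpiperazine in place of the ring, would move the number beyond the scatter remains open. As far as these compounds go, the effect of a longer or shorter chain joining the ring to the oxygen on the aromatic ring is also open.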